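The compounds below may be only part of what the source reports. "The series", "measured", "known", "first", "only" and "open" are said of these compounds alone.

Among the compounds with values here, in a functional assay on KB cells (Homo sapiens) for cytotoxicity, read by colorimetric assay and neutral red uptake, with a stated time of 72 h (on this read-out higher numbers stand for weaker inhibition and lower numbers for stronger inhibition), compound 1 (`CO[C@@H](C(=O)N[C@H]1CC[C@@H](O)CNC1=O)[C@H](O)[C@@H](O)[C@H](O)/C=C/C(C)(C)C`) gives 62600 nM, while compound 2 (`CO[C@@H](C(=O)N[C@@H]1CCCCNC1=O)[C@H](O)[C@@H](O)[C@H](O)/C=C/C(C)(C)C`) gives 1100 nM, the lower of the two numbers so far. Compound 3 (`CO[C@@H](C(=O)N[C@H]1CC[C@H](O)CNC1=O)[C@H](O)[C@@H](O)[C@H](O)/C=C/C(C)(C)C`) departs from compound 2 by one change: 6-hydroxy-2-oxoazepan-3-yl in place of 2-oxoazepan-3-yl on an amide-type nitrogen. In words, 6-hydroxy-2-oxoazepan-3-yl takes the place of 2-oxoazepan-3-yl on an amide-type nitrogen. Within the data shown here, only one measured step bears on this change, and it runs the opposite way: a 57-fold lower number from compound 1 to compound 2 (1.76 log units; beyond the scatter), a large step beyond the scatter. Compound 1 carries a group of the same name, but its structure is not identical to that of compound 3, so this step is only a loose guide. A higher number is therefore expected, though probably by less than the full size of that step. The expected step is a 5.5-fold higher number from compound 2 to compound 3 (0.74 log units; beyond the scatter). For compound 3, the estimated value is 6000 nM, with an expected range from 300 nM to 60000 nM.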

Compound 3, half-maximal inhibitory concentration: 19800 nM
Compound 3: the middle estimate sits 3.3-fold (0.52 log units) below what was measured, within the range that was stated.
By their numbers in this assay, from the lowest: compound 2; then compound 3; then compound 1.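

In this assay, an 18-fold higher number from compound 2 to compound 3 (1.26 log units; beyond the scatter) shows that the 6-hydroxy-2-oxoazepan-3-yl group gives a higher number than 2-oxoazepan-3-yl in both drawn forms, not only in the form carried by compound 1. The form of this group also counts, though less than the change itself, with a 3.2-fold lower number from compound 1 to compound 3 (0.50 log units; beyond the scatter) still beyond the scatter. That smaller step can be traced to a single feature, a stereocentre at a saturated ring carbon drawn R in compound 1 and S in compound 3, and to nothing else: the fact that compounds 1 and 3 differ only in the configuration as drawn.

The compounds shown do not say why either hydroxy form gives a higher number than compound 2. As far as these compounds go, whether an amine or a methoxy group in place of the hydroxy would also raise the number remains open.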